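Fluoro in Place of Chloro and Cytotoxicity in RD Cells

A few compounds are considered here, and "the series" means these few. Any claim that something is new, unique, unknown or untested is made for them only; others in the source may bear on it.

Compound 1 (`O=C1Nc2ccc(Cl)cc2/C1=N/NC(=S)Nc1ccccc1`): > 25000 nM
Compound 2 (`O=C1Nc2ccccc2/C1=N/NC(=S)Nc1ccc(-n2cccn2)cc1`): > 25000 nM
Compound 3 (`COc1cccc(NC(=O)N/N=C2\C(=O)Nc3ccccc32)c1`): > 25000 nM

Of the compounds shown here, three have so far been tested in an ADME assay on RD cells (Homo sapiens) for cytotoxicity (on this read-out lower numbers stand for higher toxicity in this test and higher numbers for lower toxicity in this test), and none of them yields a number. Compound 1 reaches only the assay limit, > 25000 nM. Compound 2 likewise stops at the limit, > 25000 nM. Compound 3 also ends at the limit, > 25000 nM. Compound 1 therefore stands exactly where every measured value stands, at the limit of > 25000 nM in this assay, at which 3 of the 3 values shown sit, and nothing separates it from compound 2 or compound 3.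

Compound 4 (`O=C1Nc2ccc(F)cc2/C1=N/NC(=S)Nc1ccccc1`) has not yet been measured. It differs from compound 1 in one place: fluoro in place of chloro on an aromatic carbon. Within the data shown here, no pair of measured compounds spans a single change of this kind, so no measured step can be drawn on. The step in this assay is expected to show no change beyond the usual scatter, a step that the limit leaves unreadable from compound 1 to compound 4, since compound 1 already sits at the limit of > 25000 nM in this assay, at which 3 of the 3 values shown sit. Compound 4 is accordingly estimated at 30000 nM, within a range from 15000 nM to 80000 nM, and the assay is expected most likely to report only its limit once more.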

Compound 4, half-maximal cytotoxic concentration: > 25000 nM
Compound 4: a limit, no number; the forecaster's own chance of this, stated with the estimate: 85%; the middle value lies beyond the limit too.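

In this assay compound 4 gives only a limit, > 25000 nM. Among these compounds, compound 1 gives only a limit as well, so no step between compound 1 and compound 4 can be read. The compounds shown leave open whether fluoro in place of chloro changes cytotoxicity at all, and at what concentration any of them would become cytotoxic: the limit of > 25000 nM in this assay, at which 4 of the 4 values shown sit.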